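Thioamide to carboxamide on the two cores

A few compounds are considered here, and "the series" means these few. Any claim that something is new, unique, unknown or untested is made for them only; others in the source may bear on it.

In a functional assay on KB cells (Homo sapiens) for cytotoxicity (on this read-out lower numbers stand for stronger inhibition and higher numbers for weaker inhibition), compound 2 `Cn1cc(C(=N)S)c2c(N)ncnc21` gives 15000 nM. In this assay compound 1 `Cn1cc(C(N)=O)c2c(N)ncnc21` reaches only the assay limit, > 100000 nM, which is a limit and not a number. The change a group of 3 heavy atoms (1 carbon, 1 nitrogen, 1 oxygen; no ring) in place of a group of 3 heavy atoms (1 carbon, 1 nitrogen, 1 sulfur; no ring), on an aromatic carbon gives an at least 6.6-fold higher number from compound 2 to compound 1 (0.82 log units; beyond the scatter), bounded by the limit of > 100000 nM in this assay, at which 1 of the 3 values shown sits. In this assay compound 3 `Cc1ccc(Cn2cc(C(=N)S)c3c(N)ncnc32)cc1` gives 65000 nM; the two cores differ by 4-methylphenyl in place of hydrogen on a saturated chain carbon bound to an aromatic nitrogen, which gives a 4.3-fold higher number from compound 2 to compound 3 (0.64 log units; beyond the scatter). Compound 4 `Cc1ccc(Cn2cc(C(N)=O)c3c(N)ncnc32)cc1` is not yet measured and carries the change (a group of 3 heavy atoms (1 carbon, 1 nitrogen, 1 oxygen; no ring) in place of a group of 3 heavy atoms (1 carbon, 1 nitrogen, 1 sulfur; no ring), on an aromatic carbon); this is the same kind of change as from compound 2 to compound 1, but it is made on the core of compound 3, which carries 4-methylphenyl, rather than on the core of compound 2, which carries a methyl group. In this assay a step of a 4.6-fold higher number from compound 3 to compound 4 (0.66 log units; beyond the scatter) is expected, resting on compound 2 and an at least 6.6-fold higher number from compound 2 to compound 1 (0.82 log units; beyond the scatter). Compound 4 is estimated at 300000 nM, between 100000 nM and 1000000 nM, and is expected to return a limit.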

Compound 4, half-maximal inhibitory concentration: > 100000 nM
Compound 4: only a limit was reported; the forecaster's own chance of this, stated with the estimate: 85%; the middle value is on the limit's open side.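

In this assay compound 4 returns only a limit, > 100000 nM, and not a number. Carbamoyl on the core of compound 3 gives an at least 1.5-fold higher number from compound 3 to compound 4 (0.18 log units; that floor lies within the scatter), which does not go against the step seen on the core of compound 2 but does not by itself establish a real difference on this core, and the step between the two carbamoyl compounds cannot be read. Whether the change carries over from one core to the other with the same size stays undecided: the same change on two cores in this assay, an at least 6.6-fold higher number (0.82 log units; beyond the scatter) from compound 2 to compound 1 and an at least 1.5-fold higher number (0.18 log units; that floor lies within the scatter) from compound 3 to compound 4; the limit leaves it open whether they differ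

The compounds shown leave open how a nitrile or a carboxylic acid on this aromatic carbon would read, and how an amine or a longer chain would read in place of 4-methylphenyl. Comparisons among the carbamoyl compounds stay bounded: the limit of > 100000 nM in this assay, at which 2 of the 4 values shown sit.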